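Swapping the ring-nitrogen aryl group in a cytotoxicity-silent series

The source may report more compounds than this note shows. Statements on the series, on what has been measured and on what is new or still open speak of the compounds shown alone.

Compound 1 `COc1ccc([C@H]2CC(=O)N(Cc3cccc(N)c3)C2)cc1OC1CCCC1` gives > 10000 nM in a functional assay on HEK293 cells (Homo sapiens) for cytotoxicity (a lower number here means that less compound is tolerated, a higher number that more compound is tolerated), which is a limit of the assay.
Compound 2 `COc1ccc([C@H]2CC(=O)N(c3cccc(O)c3)C2)cc1OC1CCCC1` gives > 10000 nM in this assay, which is a limit of the assay.
Compound 3 `COc1ccc([C@H]2CC(=O)N(c3ccc(C)cc3)C2)cc1OC1CCCC1` gives > 10000 nM in this assay, which is a limit of the assay.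

Compound 1 therefore stands only at a limit in this assay, and the two further values shown are limits as well: the limit of > 10000 nM in this assay, at which 3 of the 3 values shown sit. The measured steps between these three compounds are a step that the two limits leave unreadable from compound 1 to compound 2, a step that the two limits leave unreadable from compound 1 to compound 3 and a step that the two limits leave unreadable from compound 2 to compound 3; none of them yields a readable size, so no change on the amide-type nitrogen in the ring has yet moved a compound off the limit.

The unmeasured compound 4 `COc1ccc([C@H]2CC(=O)N(c3ccccc3C(F)(F)F)C2)cc1OC1CCCC1` differs from compound 1 in 2-(trifluoromethyl)phenyl in place of 3-aminobenzyl on an amide-type nitrogen in a ring. Among the compounds with values here, the steps that bear on it, from compound 1 to compound 2 and from compound 1 to compound 3, are both unreadable, so no step beyond the scatter is expected in this assay in either direction; the expected step is a step that the limit leaves unreadable from compound 1 to compound 4. Compound 4 is estimated to give 15000 nM in this assay, with a range from 7000 nM to 40000 nM, and most likely to be reported only as the same limit.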

Compound 4, half-maximal cytotoxic concentration: > 10000 nM
Compound 4: no number, only a limit; the forecaster's own chance of this, stated with the estimate: 85%; the middle value does not contradict the limit.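

Compound 4 gives > 10000 nM in this assay, which is again a limit of the assay, and the steps to it from compound 1, compound 2 and compound 3 cannot be read: the limit of > 10000 nM in this assay, at which 4 of the 4 values shown sit.

The compounds shown leave open where the half-maximal cytotoxic concentration of each truly lies, and whether any group on the amide-type nitrogen in the ring moves a compound off this limit.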